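Acetylphenyl in Place of Fluorophenyl: Expected Cytotoxicity

The source may hold more compounds than are shown below. What is called first, only, known or untested is meant among the compounds shown, and "the series" means these compounds.

Compound 2 `O=C(CCc1cccc2c1B(O)OC2)Nc1cccc(-c2ccc(F)cc2)c1` was examined in an ADME assay on WI-38 cells (Homo sapiens) for cytotoxicity, read by MTT assay, with a stated time of 72 h (on this read-out lower numbers stand for stronger inhibition and higher numbers for weaker inhibition), where compound 2 gives 4100 nM. Among the compounds with values here, of the two numbers measured so far, this is the highest; the nearest is compound 1 `COc1ccccc1NC(=O)CCc1cccc2c1B(O)OC2`, which in this assay gives 1600 nM, a gap that lies beyond the scatter. Compound 3 `CC(=O)c1cccc(-c2cccc(NC(=O)CCc3cccc4c3B(O)OC4)c2)c1` has not yet been measured in this assay. It differs from compound 2 in a single place: 3-acetylphenyl in place of 4-fluorophenyl on an aromatic carbon. Within the data shown here, no pair of measured compounds isolates this change, and compound 1 carries a different group altogether, so the measured data give no direct guide to how a 3-acetylphenyl group behaves here. The step from compound 2 to compound 3 is expected to be a 1.2-fold lower number from compound 2 to compound 3 (0.07 log units; within the scatter), that is, none beyond the scatter, with only a slight lean toward a lower number. Compound 3 is accordingly estimated at 3500 nM, within a range from 1200 nM to 10000 nM.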

Compound 3, half-maximal inhibitory concentration: 2200 nM
Compound 3: middle estimate off by 1.6-fold (0.20 log units), on the high side; the measured number falls inside the stated range.
By their numbers in this assay, from the lowest: compounds 1, 3 and 2 (each within the scatter of the next, the first and the last beyond it).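

In this assay, within the data shown here, the step is a 1.9-fold lower number from compound 2 to compound 3 (0.27 log units; within the scatter), which gives the first direct reading of a change at this position, on an aromatic carbon meta to a large group. It shows that 3-acetylphenyl can take the place of 4-fluorophenyl without moving the number beyond the scatter, even though the entering group has more heavy atoms and carries a hydrogen-bond acceptor that the leaving group lacks. No measured evidence bears on why this exchange leaves the two compounds within the scatter of each other.

This single step leaves open whether the position would tolerate groups of a different kind, such as an aminophenyl group, a carboxyphenyl group or a morpholine ring. It also cannot say whether the same exchange would give a similar step on a different amide partner of the shared core.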